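The source may report more compounds than this note shows. Statements on the series, on what has been measured and on what is new or still open speak of the compounds shown alone.

Two compounds from this series carry a shared core, a urea, and an indole-bearing sulfur link, and differ in two places at once. Compound 1 `COc1ccc(NC(=O)Nc2nc(Sc3c[nH]c4ccccc34)cc(N3CCN(c4ccccn4)CC3)n2)cc1` bears a methoxy on its outer aromatic ring together with a pyridyl-piperazine on the core. Compound 2 `O=C(Nc1ccc(Cl)cc1)Nc1nc(Sc2c[nH]c3ccccc23)cc(N2CCCC2)n1` bears a chloro on that ring together with a pyrrolidine on the core. In a functional assay on HepG2 cells (Homo sapiens) for inhibition, with a stated time of 72 h (on this read-out lower numbers stand for stronger inhibition and higher numbers for weaker inhibition), compound 1 gives 11400 nM. In this assay compound 2 gives 7870 nM, which stands as the lowest of the two numbers, though its gap to compound 1 lies within the usual scatter.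

Compound 3 `COc1ccc(NC(=O)Nc2nc(Sc3c[nH]c4ccccc34)cc(N3CCCC3)n2)cc1` keeps the pyrrolidine of compound 2 and changes only the outer ring: methoxy in place of chloro on an aromatic carbon. Among the measured compounds shown here, no pair in the data isolates this exchange, so the two measured values offer no guide to its size. Compound 3 is therefore expected to land close to compound 2, with an estimated step of a 1.1-fold higher number from compound 2 to compound 3 (0.06 log units; within the scatter), that is, none beyond the scatter. The estimate for compound 3 in this assay is 9000 nM, with a range from 4000 nM to 20000 nM.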

Compound 3, half-maximal inhibitory concentration: 20300 nM
Beside the measured number, compound 3's estimate is 2.3-fold (0.35 log units) below it, outside the stated range (above it).
By their numbers in this assay, from the lowest: compounds 2, 1 and 3 (each within the scatter of the next, the first and the last beyond it).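

With the pyrrolidine held fixed, the outer ring can now be read on its own: in this assay, methoxy in place of chloro on an aromatic carbon, para to a large group, gives a 2.6-fold higher number from compound 2 to compound 3 (0.41 log units; beyond the scatter) and this modest step lies beyond the scatter. This shows that the position responds to a change of group, with the chloro compound giving the lower number and so the stronger inhibition of this pair. With the methoxy held fixed, pyrrolidin-1-yl in place of 4-(pyridin-2-yl)piperazin-1-yl on the core gives a 1.8-fold higher number from compound 1 to compound 3 (0.25 log units; within the scatter) and this step stays within the scatter, so this exchange on the core cannot be told apart from ordinary variation between repeated measurements.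

Nothing at hand gives a reason for the step on the outer ring. Only chloro and methoxy are shown at that position, so it remains open where a fluoro group, an amine or a carboxylic acid would fall, and whether methoxy in place of chloro gives a similar step with 4-(pyridin-2-yl)piperazin-1-yl on the core.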